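Replacing the 1,2-oxazole group of compound 2

A few compounds are considered here, and "the series" means these few. Any claim that something is new, unique, unknown or untested is made for them only; others in the source may bear on it.

- Compound 1 `CCOCCOC(=O)C(=O)Nc1nc(-c2cc(OC)no2)cs1`: 3 mg/kg
- Compound 2 `CCOCCOC(=O)C(=O)Nc1nc(-c2cc(COC)no2)cs1`: 2.4 mg/kg

In a functional assay on the whole organism with Rattus norvegicus as the target (a lower number here means that less compound is needed, a higher number that more compound is needed for the effect), compound 2 gives 2.4 mg/kg and compound 1 gives 3 mg/kg, two values within the usual scatter of each other. In compound 3 `CCOCCOC(=O)C(=O)Nc1nc(-c2conc2C)cs1`, the shared core stays, while 3-methyl-1,2-oxazol-4-yl takes the place of 3-(methoxymethyl)-1,2-oxazol-5-yl on an aromatic carbon (3-methyl-1,2-oxazol-4-yl in place of 3-(methoxymethyl)-1,2-oxazol-5-yl on an aromatic carbon). Going by the values given here, only one measured step bears on this change: a 1.3-fold lower number from compound 1 to compound 2 (0.10 log units; within the scatter), with methoxymethyl in place of methoxy on an aromatic carbon. Among the compounds with values here, that step stayed within the scatter, but it is a single small comparison, and no measured compound carries the 3-methyl-1,2-oxazol-4-yl group. With so little evidence, no shift beyond the scatter is expected in either direction, and the uncertainty is wide. The expected change is a 1.3-fold higher number from compound 2 to compound 3 (0.10 log units; within the scatter). Compound 3 is estimated at 3 mg/kg, with an expected range of 1 mg/kg to 9 mg/kg.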

Compound 3, dose for half-maximal effect: > 100 mg/kg
Compound 3 was reported as a limit; the forecaster's own chance of this, stated with the estimate: 5%; middle value at least 33-fold (1.52 log units) away from the limit.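

Exchanging 3-(methoxymethyl)-1,2-oxazol-5-yl for 3-methyl-1,2-oxazol-4-yl gives an at least 41-fold higher number from compound 2 to compound 3 (1.61 log units; beyond the scatter) in this assay, and exchanging 3-methoxy-1,2-oxazol-5-yl for the same group gives an at least 33-fold higher number from compound 1 to compound 3 (1.52 log units; beyond the scatter). So this position on the shared core, next to the ring nitrogen, is far less tolerant than the earlier comparison suggested: the small change within the 1,2-oxazol-5-yl series stayed within the scatter, whereas this change of ring group goes well beyond it. The value of compound 3 is a limit, so the true size of both steps stays unknown: the limit of > 100 mg/kg in this assay, at which 1 of the 3 values shown sits.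

The change to compound 3 alters both how the ring is attached and the group it carries, and the compounds shown cannot separate these two effects. Going by these compounds, it remains open whether 3-methyl-1,2-oxazol-5-yl, which keeps the ring attachment of compound 1 and compound 2, would retain the effect.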